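Chalcone series: fluorophenyl to tolyl on the enone arm

The source may hold more compounds than are shown below. What is called first, only, known or untested is meant among the compounds shown, and "the series" means these compounds.

Working notes on a small chalcone set tested in an assay on isolated protein for inhibition of Amine oxidase [flavin-containing] B (Homo sapiens); a higher number here means a weaker inhibitor, a lower number a stronger inhibitor. Compound 1 `O=C(/C=C/c1ccccc1F)c1ccc(-n2ccnc2)cc1` carries a 2-fluorophenyl on the enone chain. In this assay compound 1 gives only a limit, > 10000 nM, not a number; this is the limit of > 10000 nM in this assay, at which 1 of the 2 values shown sits. Compound 2 `COc1ccc(C(=O)/C=C/c2ccc(O/N=C(\C)c3ccc(OC)cc3)cc2)cc1` belongs to a different part of the series and also reaches only a limit in this assay, > 200 nM, which is the limit of > 200 nM in this assay, at which 1 of the 2 values shown sits. Among the compounds with values here, with both measured entries sitting at limits, compound 1 cannot be placed on a scale against compound 2, and no measured step exists in the set.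

Compound 3 `Cc1ccc(/C=C/C(=O)c2ccc(-n3ccnc3)cc2)cc1` is the next entry and differs from compound 1 in one place: 4-methylphenyl in place of 2-fluorophenyl on a double-bonded chain carbon bound to a double-bonded chain carbon. Within the data shown here, no step between measured compounds is available to calibrate this change, so the expectation rests on compound 1 alone, which sits at its limit > 10000 nM. The step from compound 1 to compound 3 is expected to be small to moderate, most likely toward a stronger inhibitor, an at least 1.2-fold lower number from compound 1 to compound 3 (0.09 log units; that floor lies within the scatter), but with little confidence that it escapes the scatter. Compound 3 is estimated at 8000 nM in this assay, within a range of 1500 nM to 40000 nM.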

Compound 3, half-maximal inhibitory concentration: 320 nM
The estimate for compound 3 lay 25-fold (1.40 log units) above the measured number; the whole stated range lies above it.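

Within the data shown here, replacing 2-fluorophenyl with 4-methylphenyl on a double-bonded chain carbon bound to a double-bonded chain carbon gives the first readable step in the set: in this assay the change produces an at least 31-fold lower number from compound 1 to compound 3 (1.49 log units; beyond the scatter). This shows that the aryl group at this place on the enone arm can decide whether the imidazolyl-bearing chalcone gives a measurable number, even though the two groups have equal heavy-atom counts and each is a six-membered aromatic ring of carbon only. The true size of the step remains unknown, and the printed figure is only a floor, because compound 1 stands at a limit rather than a number: the limit of > 10000 nM in this assay, at which 1 of the 3 values shown sits.

This single step changes the substituent and its place on the ring together, so it leaves open whether the gain follows the arrival of the methyl, the loss of the fluorine or the change of place. Plain phenyl, 4-fluorophenyl and 2-methylphenyl on the same carbon would separate those readings, while 4-methoxyphenyl, 4-aminophenyl and 4-carboxyphenyl would test how far the result at this place extends beyond a methyl.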